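Notes on the series: compound 1 to compound 3

The source may hold more compounds than are shown below. What is called first, only, known or untested is meant among the compounds shown, and "the series" means these compounds.

In a functional assay on CCRF-CEM cells (Homo sapiens) for antiproliferative activity (a higher number here means that more compound is tolerated, a lower number that less compound is tolerated), compound 1 (`Cc1cn(C2OC(CO[Si](C)(C)C(C)(C)C)C3(OS(=O)(=O)C=C3N)C2O[Si](C)(C)C(C)(C)C)c(=O)n(CCCNC(=O)[C@H](C)NC(=O)[C@@H](N)C(C)C)c1=O`) gives 11000 nM, level with compound 2 (`Cc1cn(C2OC(CO[Si](C)(C)C(C)(C)C)C3(OS(=O)(=O)C=C3N)C2O[Si](C)(C)C(C)(C)C)c(=O)n(CCCNC(=O)[C@H](CC(C)C)NC(=O)[C@@H](N)C(C)C)c1=O`) at 11000 nM. Compound 3 (`Cc1cn(C2OC(CO[Si](C)(C)C(C)(C)C)C3(OS(=O)(=O)C=C3N)C2O[Si](C)(C)C(C)(C)C)c(=O)n(CCCNC(=O)[C@@H](N)C(C)C)c1=O`) is still unmeasured. The change to it is 1-amino-2-methylpropyl in place of 1-(((1-amino-2-methylpropyl)carbonyl)amino)ethyl on a carbonyl carbon. Among the measured compounds shown here, the only measured step is no change at the digits printed from compound 1 to compound 2 (within the scatter), and it swaps isopropyl for hydrogen on a saturated chain carbon, so it covers this larger truncation only loosely. The expected step is no change at the digits printed from compound 1 to compound 3 (within the scatter), with nothing expected beyond the scatter, in either direction. For compound 3 the estimated value is 11000 nM, with an expected range of 5500 nM to 22000 nM.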

Compound 3, half-maximal cytotoxic concentration: 9600 nM
The estimate for compound 3 lay 1.1-fold (0.06 log units) above the measured number, and the stated range covers the measured number.
By their numbers in this assay, from the lowest: compounds 3, 1 and 2 (each within the scatter of the next).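

In this assay, 1-amino-2-methylpropyl in place of 1-(((1-amino-2-methylpropyl)carbonyl)amino)ethyl on a carbonyl carbon gives a 1.1-fold lower number from compound 1 to compound 3 (0.06 log units; within the scatter). The earlier step altered only one side chain within this unit, whereas this one removes the whole unit without a step beyond the scatter. Nothing available explains this result. As far as these compounds go, all three compounds keep the 1-amino-2-methylpropyl group or its amine, so the outcome with a carboxylic acid or a plain methyl on that carbonyl carbon remains open.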